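A Formyl Group Added to the Aromatic Ring of Compound 2

The source may report more compounds than this note shows. Statements on the series, on what has been measured and on what is new or still open speak of the compounds shown alone.

Of the compounds shown here, three have been tested in a functional assay on K562 cells (Homo sapiens) for inhibition; on this read-out higher numbers stand for weaker inhibition and lower numbers for stronger inhibition. Compound 1 `CCCC#Cc1cc(C)oc(=O)c1` gives 17800 nM. Compound 2 `Cc1cc(-c2ccccc2)cc(=O)o1` shows only > 50000 nM, which is a limit of the assay rather than a number. Compound 3 `CCCCc1cc(C)oc(=O)c1` likewise shows only the limit > 50000 nM. Compound 2 thus stands at the limit of > 50000 nM in this assay, at which 2 of the 3 values shown sit, so its true potency is not known beyond being weak. Compound 4 `Cc1cc(-c2ccc(C=O)cc2)cc(=O)o1` differs from compound 2 by formyl in place of hydrogen on an aromatic carbon. For the measured compounds named here, no step between measured compounds exists to guide this change. In this assay the step is expected to be a number no higher from compound 2 to compound 4 (the limit leaves the size open), small or none beyond the scatter. Compound 4 is therefore expected to give about 50000 nM, within 15000 nM to 150000 nM.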

Compound 4, half-maximal inhibitory concentration: 26000 nM
For compound 4 the middle estimate is 1.9-fold (0.28 log units) above the measured one; low and high end bracket the measured number.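

In this assay, the change reads as an at least 1.9-fold lower number from compound 2 to compound 4 (0.28 log units; that floor lies within the scatter). This shows that an aromatic carbon para to a group of 8 heavy atoms can carry formyl while inhibition stays measurable as a number. The real size of the step cannot be read, because compound 2 gives only a limit: the limit of > 50000 nM in this assay, at which 2 of the 4 values shown sit.

The compounds shown leave open whether inhibition truly improves beyond the scatter. They also leave open whether formyl itself matters, or whether an amine or a carboxylic acid on the same carbon would give a similar number.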